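Replacing the fluorophenyl with a dihydroxyphenyl ring

The compounds below may be only part of what the source reports. "The series", "measured", "known", "first", "only" and "open" are said of these compounds alone.

Of the compounds shown here, three sharing one core have been tested in a functional assay on U-87MG ATCC cells (Homo sapiens) for cytotoxicity, read by MTT assay, with a stated time of 72 h; on this read-out lower numbers stand for stronger inhibition and higher numbers for weaker inhibition. Compound 3 `CN(C)CCn1cnnc1-c1cc(Oc2ccc(NC(=O)N/N=C/c3ccc(F)cc3)cc2F)ccn1` gives 2310 nM, and compound 1 `CN(C)CCn1cnnc1-c1cc(Oc2ccc(NC(=O)N/N=C/c3ccc(Cl)cc3Cl)cc2F)ccn1` gives 2330 nM; the step of a 1.0-fold lower number from compound 1 to compound 3 (0.00 log units; within the scatter) lies within the scatter, so the two are indistinguishable. Compound 2 `COc1ccc(OC)c(/C=N/NC(=O)Nc2ccc(Oc3ccnc(-c4nncn4CCN(C)C)c3)c(F)c2)c1` gives 6400 nM, and the step of a 2.8-fold lower number from compound 2 to compound 3 (0.44 log units; beyond the scatter) is modest but beyond the scatter. Compound 4 `CN(C)CCn1cnnc1-c1cc(Oc2ccc(NC(=O)N/N=C/c3ccc(O)c(O)c3)cc2F)ccn1` differs from compound 3 by 3,4-dihydroxyphenyl in place of 4-fluorophenyl on a carbon with a double bond to nitrogen. Going by the values given here, the only guide is compound 2, where an oxygen-bearing ring gave the step of a 2.7-fold higher number from compound 1 to compound 2 (0.44 log units; beyond the scatter), whereas the halogen swap from compound 1 to compound 3 changed nothing. By analogy a modest rise is expected, a 1.9-fold higher number from compound 3 to compound 4 (0.29 log units; within the scatter). Compound 4 is therefore estimated at 4500 nM in this assay, within 1500 nM to 13000 nM.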

Compound 4, half-maximal inhibitory concentration: > 100000 nM
Compound 4 gave a limit, no number; the forecaster's own chance of this, stated with the estimate: 5%; middle value at least 22-fold (1.34 log units) from the limit.
By their numbers in this assay, from the lowest: compounds 3 and 1 (each within the scatter of the next); then compound 2. At a limit, above all of these: compound 4.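

Compound 4 gives a limit, not a number, in this assay: the limit of > 100000 nM in this assay, at which 1 of the 4 values shown sits. The position on the carbon with a double bond to nitrogen therefore tolerates halogen swaps but is far from indifferent to what the ring carries, as the 3,4-dihydroxyphenyl ring brings an at least 43-fold higher number from compound 3 to compound 4 (1.63 log units; beyond the scatter) and an at least 42-fold higher number from compound 1 to compound 4 (1.63 log units; beyond the scatter). Oxygen on the ring alone does not produce so large a change, since the 2,5-dimethoxyphenyl ring still gives a measurable value and the 3,4-dihydroxyphenyl ring brings an at least 15-fold higher number from compound 2 to compound 4 (1.19 log units; beyond the scatter). Going by these compounds, it remains open how a ring with a single hydroxyl would read. A ring bearing an amine or a carboxylic acid is also left open.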